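Adding a second trifluoromethyl group to compound 1

The compounds below may be only part of what the source reports. "The series", "measured", "known", "first", "only" and "open" are said of these compounds alone.

In a functional assay on DU-145 cells (Homo sapiens) for antiproliferative activity, read by propidium iodide staining, with a stated time of 96 h (on this read-out higher numbers stand for weaker inhibition and lower numbers for stronger inhibition), compound 1 (`CC(O)(CSc1cccc(C(F)(F)F)c1)C(=O)Nc1ccc(S(F)(F)(F)(F)F)cc1`) gives 26200 nM. Among the measured compounds shown here, the only other measured compound, compound 2 (`CC(O)(CSc1ccccc1C(F)(F)F)C(=O)Nc1ccc(S(F)(F)(F)(F)F)cc1`), gives 15800 nM. These two values lie within the scatter of each other, so compound 1 has no clear rank on the numbers available.

Compound 3 (`CC(O)(CSc1cc(C(F)(F)F)cc(C(F)(F)F)c1)C(=O)Nc1ccc(S(F)(F)(F)(F)F)cc1`) has not yet been measured. It keeps the core of compound 1 and carries one change, trifluoromethyl in place of hydrogen on an aromatic carbon.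

For the measured compounds named here, only one measured step bears on this change: a 1.7-fold lower number from compound 1 to compound 2 (0.22 log units; within the scatter). That step relocates the existing trifluoromethyl group and adds no second one, so it is an indirect guide. Going by the values given here, no measured step adds such a group, and the data therefore indicate no direction for this change. No step beyond the scatter is expected in this assay, although the uncertainty is wide.

Compound 3 is expected at about 20000 nM, with an estimated range of 8000 nM to 45000 nM. The expected change is a 1.3-fold lower number from compound 1 to compound 3 (0.12 log units; within the scatter).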

Compound 3, half-maximal inhibitory concentration: 29700 nM
Compound 3: the middle estimate sits 1.5-fold (0.17 log units) below what was measured; measured number inside the range.
By their numbers in this assay, from the lowest: compounds 2, 1 and 3 (each within the scatter of the next).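

Compound 3 gives the first measured case of a second trifluoromethyl group on this ring, since the earlier pair only relocated a single one. In this assay, trifluoromethyl entering in place of hydrogen on an aromatic carbon, meta to a trifluoromethyl group, gives a 1.1-fold higher number from compound 1 to compound 3 (0.05 log units; within the scatter), so at this position the added group leaves the read-out unchanged within the scatter. No measurement at hand offers an explanation for this outcome.

The compounds shown leave open whether a different group at this same position, such as an amine, a carboxylic acid or a methoxy group, would move the number beyond the scatter, or whether the tolerance seen here is specific to trifluoromethyl. They also leave open whether the pentafluorosulfanyl group or the hydroxyl group of the shared core matters for activity in this assay, as neither changes in the compounds shown, and replacing either with, for example, a chlorine atom or a hydrogen atom would be needed to tell.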